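Compound 2 to compound 4: a chain in place of a ring

The compounds below may be only part of what the source reports. "The series", "measured", "known", "first", "only" and "open" are said of these compounds alone.

Compound 1, `Nc1scc(CN2CCN(c3cc(Cl)cc(Cl)c3)CC2)c1C(=O)c1ccc(Cl)cc1`: -1%
Compound 2, `Nc1scc(CN2CCN(c3ccc(Cl)cc3F)CC2)c1C(=O)c1ccc(Cl)cc1`: -9.2%
Compound 3, `COc1ccc(N2CCN(Cc3csc(N)c3C(=O)c3ccc(Cl)cc3)CC2)cc1`: -1.2%

All three compounds were tested in a functional assay on CHO cells with adenosine receptor A1 (Homo sapiens) as the target, read by cAMP accumulation and immunoassay, with a stated time of 6 min, tested at 0.01 uM; a lower number here means a stronger effect, a higher number a weaker effect of the compound at the concentration tested. Compound 2 gives the lowest of the three numbers, yet its neighbours sit close: the step from compound 1 was a number 8.2 percentage points lower from compound 1 to compound 2 (within the scatter), and the step onward to compound 3 is a number 8 percentage points higher from compound 2 to compound 3 (within the scatter). Compound 1 and compound 3 are also near each other, a number 0.2 percentage points lower from compound 1 to compound 3 (within the scatter). Every measured step therefore falls within the scatter, and the three values all lie near zero.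

Compound 4 is `Nc1scc(CN2CCN(CCCc3ccc(Cl)cc3)CC2)c1C(=O)c1ccc(Cl)cc1`. It differs from compound 2 in one place: 3-(4-chlorophenyl)propyl in place of 4-chloro-2-fluorophenyl on an amine nitrogen in a ring. The measured steps each exchanged one six-membered aromatic ring on that ring nitrogen for another such ring, and none of them moved the read-out beyond the scatter. Going by the values given here, no measured step brings a 3-(4-chlorophenyl)propyl chain onto that nitrogen, so the new change is only loosely covered by what is known. Given that the three aromatic groups gave indistinguishable read-outs, the expected step in this assay for compound 4 is none beyond the scatter, a number 5.2 percentage points higher from compound 2 to compound 4 (within the scatter). Compound 4 is accordingly estimated at -4%, with a range from -18% to 10%.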

Compound 4, a percentage reported as activity, at one concentration (the size of the read-out at that concentration, not a potency): 0%
Compound 4: middle estimate off by 4 percentage points, on the low side; the measured number falls inside the stated range.
By their numbers in this assay, from the lowest: compounds 2, 3, 1 and 4 (each within the scatter of the next).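

In this assay, going by these compounds alone, the earlier steps only exchanged one six-membered aromatic ring on the amine nitrogen in a ring for another, whereas compound 4 puts a 3-(4-chlorophenyl)propyl chain in that place, and the read-out still does not separate from any of its neighbours: a number 9.2 percentage points higher from compound 2 to compound 4 (within the scatter) and a number 1.2 percentage points higher from compound 3 to compound 4 (within the scatter) and a number 1 percentage points higher from compound 1 to compound 4 (within the scatter) in turn. The finding new to this position is thus that the aromatic ring need not sit directly on that nitrogen for the read-out at this one concentration to stay within the scatter of the three compounds that carry it there, so all four compounds remain undistinguished. Nothing available bears on why the read-out stays put when a chain takes the place of the ring.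

The compounds shown leave open whether a benzyl group, a longer chain or a chain without the chlorine on its ring would behave in the same way. Within the data shown here, they also leave open whether a chain ending in an amine or a carboxylic acid, in that same place on the nitrogen, would bring the first step beyond the scatter.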